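Hydroxycarbamoyl-cyclopropyl analogue in the thiazole anilide series

The source may hold more compounds than are shown below. What is called first, only, known or untested is meant among the compounds shown, and "the series" means these compounds.

Among the compounds with values here, compound 1 `Cc1nc(-c2ccc(C(F)(F)F)cc2)sc1CNc1ccc(C(=O)O)cc1` gives 10% in a functional assay on CHO cells for agonist activity at Free fatty acid receptor 1 (Homo sapiens), read by a luciferase reporter (a lower number here means a smaller maximal response, a higher number a larger maximal response), while compound 2 `Cc1nc(-c2ccc(C(F)(F)F)cc2)sc1CNc1ccc(CCC(N)=O)cc1` gives 88%, the higher of the two numbers; the single step of a number 78 percentage points higher from compound 1 to compound 2 (beyond the scatter) is the only one in hand. Compound 3 `Cc1nc(-c2ccc(C(F)(F)F)cc2)sc1CNc1ccc([C@H]2C[C@@H]2C(=O)NO)cc1` carries the change (2-(hydroxycarbamoyl)cyclopropyl in place of 2-carbamoylethyl on an aromatic carbon). Within the data shown here, no measured step covers this exact exchange; the one step available shows that altering the group at this position can shift the maximal response by a large amount, so a sizeable step is plausible in either direction. A moderate downward step a number 28 percentage points lower from compound 2 to compound 3 (beyond the scatter) is expected, giving an estimate for compound 3 of 60% (range 25% to 95%).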

Compound 3, largest response reached (reported as percent of maximum), in percent of the reference or control that the assay uses: 78%
For compound 3 the middle estimate is 18 percentage points below the measured one; the measured number falls inside the stated range.
By their numbers in this assay, from the lowest: compound 1; then compounds 3 and 2 (each within the scatter of the next).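

The step of a number 10 percentage points lower from compound 2 to compound 3 (within the scatter) shows that, in this assay, 2-(hydroxycarbamoyl)cyclopropyl, with its three-membered ring and 2 defined stereocentres, can take the place of 2-carbamoylethyl para to a large group with the two compounds remaining within the scatter. The step of a number 68 percentage points higher from compound 1 to compound 3 (beyond the scatter) gives a second group clearly separated from carboxy at this position. No supporting measurement bears on these results.

Open, going by these compounds, is whether the cyclopropyl ring or the hydroxycarbamoyl group matters more, a question that a cyclopropyl bearing a primary amide or a carboxylic acid would address. On these data alone, the opposite configuration at the 2 stereocentres also remains open.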